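A few compounds are considered here, and "the series" means these few. Any claim that something is new, unique, unknown or untested is made for them only; others in the source may bear on it.

Of the compounds shown here, three built on one shared core have been tested in a functional assay on MDA-MB-231 cells (Homo sapiens) for cytotoxicity, read by MTT assay, with a stated time of 72 h; on this read-out lower numbers stand for stronger inhibition and higher numbers for weaker inhibition. Compound 1 `Cc1ccc(-c2ccc(C)n2-c2ccc(-c3nc4ccccc4s3)cc2)cc1` gives 17800 nM. Compound 2 `Cc1ccc(-c2ccc(C)n2-c2ccc(-c3nc4ccc(F)cc4s3)cc2)cc1` gives 16700 nM. Compound 3 `COc1ccc(-c2ccc(C)n2-c2ccc(-c3nc4ccc(F)cc4s3)cc2)cc1` gives 19000 nM. Compound 2 sits at one end of these three numbers, yet its gaps to the other two are both within the scatter, so the three compounds cannot be told apart on these readings.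

Two single-point changes have been measured. Putting fluoro in place of hydrogen on an aromatic carbon gave a 1.1-fold lower number from compound 1 to compound 2 (0.03 log units; within the scatter). Putting methoxy in place of methyl on an aromatic carbon gave a 1.1-fold higher number from compound 2 to compound 3 (0.06 log units; within the scatter).

Compound 4 `COc1ccc2nc(-c3ccc(-n4c(C)ccc4-c4ccc(C)cc4)cc3)sc2c1` has not yet been measured. Relative to compound 2 the change is methoxy in place of fluoro on an aromatic carbon. The first measured step touched the same ring with a fluoro group and the second introduced a methoxy group elsewhere on the molecule; neither moved the number beyond the scatter. On that basis the new change is expected to produce no step beyond the scatter in this assay, in either direction. Compound 4 is therefore estimated to give 18000 nM, with a range from 9000 nM to 36000 nM, which means an expected step of a 1.1-fold higher number from compound 2 to compound 4 (0.03 log units; within the scatter).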

Compound 4, half-maximal inhibitory concentration: 20500 nM
For compound 4 the middle estimate is 1.1-fold (0.06 log units) below the measured one; the measured number falls inside the stated range.
By their numbers in this assay, from the lowest: compounds 2, 1, 3 and 4 (each within the scatter of the next).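

In this assay, this position on the six-membered aromatic ring of carbon only has now carried hydrogen, fluoro and methoxy, with the rest of the molecule held the same. Methoxy in place of fluoro gives a 1.2-fold higher number from compound 2 to compound 4 (0.09 log units; within the scatter) and methoxy in place of hydrogen gives a 1.2-fold higher number from compound 1 to compound 4 (0.06 log units; within the scatter) in the same comparison set, so neither swap separates the compounds. Before this result, only the small fluoro had been tried at this position; methoxy brings two heavy atoms and a hydrogen-bond acceptor to the same carbon, and the readings still cannot be told apart, a finding for which no outside data offer an explanation.

What the compounds shown leave open is whether a quite different group at this position, such as an amine, a carboxylic acid or a longer chain like butoxy, would give a step beyond the scatter. They also leave open whether changes elsewhere on the shared core, for example replacing the methyl on the five-membered ring with an amine, would move the number in this cell assay at all.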